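Phenyl for Benzyl on the Ring Nitrogen: Expected Recovery

The source may report more compounds than this note shows. Statements on the series, on what has been measured and on what is new or still open speak of the compounds shown alone.

Compound 1 `O=C(c1nn(-c2ccccc2)c2c1CC(NCc1ccccc1)CC2)N1CCCCC1`: 501 nM
Compound 2 `O=C(c1nn(Cc2ccccc2)c2c1CC(NCc1ccc(F)cc1)CC2)N1CCCCC1`: > 10000 nM

In an assay on isolated protein for antagonist activity at Sigma intracellular receptor 2 (Homo sapiens), read by scintillation counting, with a stated time of 120 min, in the presence of a further agent that is not named here (a higher number here means a weaker inhibitor, a lower number a stronger inhibitor), compound 1 gives 501 nM. Compound 2 reaches only > 10000 nM, which is a limit of the assay and not a number. Going by these compounds, compound 2 therefore stands at the limit of > 10000 nM in this assay, at which 1 of the 2 values shown sits, so its true strength is unknown beyond that boundary. Going by the values given here, compound 1 and compound 2 differ in two places at once, so their two values show only that the pair spans from a measurable figure to the limit.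

Compound 3 `O=C(c1nn(-c2ccccc2)c2c1CC(NCc1ccc(F)cc1)CC2)N1CCCCC1` is not yet measured. It differs from compound 2 by phenyl in place of benzyl on an aromatic nitrogen. With this change compound 3 carries the same group on the aromatic nitrogen as compound 1, keeping only the fluorine on the benzyl amine as a difference from compound 1. Because compound 1 gives 501 nM, compound 3 is expected to come back into the measurable range, and the step of an at least 14-fold lower number from compound 2 to compound 3 (1.15 log units; beyond the scatter) is expected to be a large gain in inhibition. The estimate for compound 3 is 700 nM, expected to lie between 200 nM and 3000 nM.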

Compound 3, inhibition constant: > 10000 nM
Compound 3 ended at the assay's limit (the forecaster's own chance of this, stated with the estimate: 15%); at least 14-fold (1.15 log units) between middle value and limit.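

In this assay compound 3 gives > 10000 nM and this is a limit of the assay, not a number, so phenyl on the aromatic nitrogen does not by itself give a measurable value. Going by these compounds alone, the one readable comparison has fluoro in place of hydrogen on an aromatic carbon as its only change, with an at least 19-fold higher number from compound 1 to compound 3 (1.30 log units; beyond the scatter) and thus a large loss of inhibition, which the earlier compounds could not show. The step from benzyl to phenyl cannot be read, because both of its ends are limits: the limit of > 10000 nM in this assay, at which 2 of the 3 values shown sit.

Going by these compounds, how far compound 2 and compound 3 truly lie past the limit remains open, so the effect of the ring nitrogen group on the fluorinated compounds is unknown. On these data alone, it is also open whether chloro or methoxy in place of that fluoro would give a measurable value.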